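From acetyl to 3,5-diaminophenyl on the shared core

This account rests on a few compounds, and the source may have more. Where it says the series, first, only, none or still open, it means among the compounds named here.

In a functional assay on HEK293 cells (Homo sapiens) for cytotoxicity (a higher number here means that more compound is tolerated, a lower number that less compound is tolerated), compound 1 (`COc1ccc([C@H]2CC(=O)N(Cc3cccc(C#N)c3)C2)cc1OC1CCCC1`) gives > 10000 nM as a limit of the assay. Compound 2 (`COc1ccc([C@H]2CC(=O)N(C(C)=O)C2)cc1OC1CCCC1`) gives > 10000 nM and this too is only a limit. Among the compounds with values here, the one measured step is a step that the two limits leave unreadable from compound 1 to compound 2 and offers no size to carry forward. Within the data shown here, compound 1 and compound 2 share the limit of > 10000 nM in this assay, at which 2 of the 2 values shown sit, as their only reading. Compound 3 (`COc1ccc([C@H]2CC(=O)N(c3cc(N)cc(N)c3)C2)cc1OC1CCCC1`) carries 3,5-diaminophenyl in place of acetyl on an amide-type nitrogen in a ring, with the difference being 3,5-diaminophenyl in place of acetyl on an amide-type nitrogen in a ring in full. With no readable size to draw on, the expected change is a step that the limit leaves unreadable from compound 2 to compound 3 by this estimate, with no clear direction. Compound 3 is expected at 15000 nM with an estimated range from 4000 nM to 40000 nM in this assay as well.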

Compound 3, half-maximal cytotoxic concentration: > 10000 nM
Compound 3: only a limit was reported; the forecaster's own chance of this, stated with the estimate: 75%; the middle value is on the limit's open side.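

No step from compound 1 or compound 2 to compound 3 can be read, since all their readings are limits: the limit of > 10000 nM in this assay, at which 3 of the 3 values shown sit.

The compounds shown leave open whether any of these groups on the amide-type nitrogen in a ring changes the reading in this assay.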